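The source may hold more compounds than are shown below. What is called first, only, known or untested is meant among the compounds shown, and "the series" means these compounds.

Three compounds built on a shared core that carries an oxime have been examined in a physicochemical assay for lipophilicity; on this read-out lower numbers stand for lower lipophilicity and higher numbers for higher lipophilicity. Compound 1 `C[n+]1ccn(COCC[Si](C)(C)C)c1/C=N/O` is the only one of them with a definite number: in this assay compound 1 gives -0.34. Compound 2 `C[n+]1ccn(CCCC#N)c1/C=N/O` differs from it in its side chain. For compound 2 this assay reports only a limit, < -3, and not a number. Compound 3 `C[n+]1ccn(COCC[N+](=O)[O-])c1/C=N/O` carries yet another side chain, and for compound 3 this assay gives no result reported. Compound 2 therefore stands at the edge of what this assay can report, a point that the line the limit of < -3 in this assay, at which 1 of the 3 values shown sits, records.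

Compound 4 `CN(C)CCn1cc[n+](C)c1/C=N/O` has not yet been measured in this assay. Set against compound 2, the change is dimethylamino in place of cyanomethyl on a saturated chain carbon, two bonds along the chain from an aromatic nitrogen. Going by the values given here, no pair of measured compounds differing in a single place exists here, so the size of such a step cannot be read from the data. The step from compound 2 to compound 4 is expected to be a number no lower from compound 2 to compound 4 (the limit leaves the size open). Compound 4 is accordingly expected to come out near -3, in a range from -4 to -2, with a real chance that this assay again reports only a limit rather than a number.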

Compound 4, distribution coefficient: -3.06
The estimate for compound 4 lay 0.06 log units above the measured number; low and high end bracket the measured number.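

The size of the change from compound 2 to compound 4 in this assay cannot be read, because compound 2 carries a limit and not a number: the limit of < -3 in this assay, at which 1 of the 4 values shown sits.

The compounds shown leave open how far, and in which direction, dimethylamino in place of cyanomethyl moves the read-out.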